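Removing one hydroxy group from compound 2

The source may report more compounds than this note shows. Statements on the series, on what has been measured and on what is new or still open speak of the compounds shown alone.

Compound 1 `CC1=C(/C=C/C(C)=C/C=C/C(C)=C\C(=O)Nc2ccc(O)cc2)C(C)(C)CCC1n1ccnc1` gives 13100 nM in a functional assay on MDA-MB-231 cells (Homo sapiens) for inhibition, read by MTT assay; on this read-out lower numbers stand for stronger inhibition of growth and higher numbers for weaker inhibition of growth
Compound 2 `CC1=C(/C=C/C(C)=C/C=C/C(C)=C\C(=O)NCc2ccc(O)cc2)C(C)(C)CCC1n1ccnc1` gives 2230 nM in this assay

Compound 2 holds the lower of these two numbers, so it is the stronger growth inhibitor of the pair, and the gap lies beyond the usual scatter. Compound 3 `CC1=C(/C=C/C(C)=C/C=C/C(C)=C\C(=O)NCc2ccccc2)C(C)(C)CCC1n1ccnc1` keeps the shared core and the amide-type nitrogen of compound 2 but carries benzyl instead of 4-hydroxybenzyl. The change is hydrogen in place of hydroxy on an aromatic carbon and consists of hydrogen in place of hydroxy on an aromatic carbon, para to a large group.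

One measured step offers indirect guidance. The step of a 5.9-fold lower number from compound 1 to compound 2 (0.77 log units; beyond the scatter) came with 4-hydroxybenzyl in place of 4-hydroxyphenyl, and both of those compounds keep the hydroxy group. Going by these compounds, no measurement therefore shows what losing that group does, and the direction remains open. The modest size of that step argues against assuming a large change here. The expected result in this assay is a 1.1-fold higher number from compound 2 to compound 3 (0.05 log units; within the scatter) and would probably stay within the scatter. Compound 3 is estimated at 2500 nM in this test. The expected range for compound 3 runs from 900 nM to 7000 nM on repeated measurement.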

Compound 3, concentration for 50% growth inhibition: 5880 nM
Compound 3: middle estimate off by 2.4-fold (0.37 log units), on the low side, and the stated range covers the measured number.
By their numbers in this assay, from the lowest: compound 2; then compound 3; then compound 1.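

Compound 2 and compound 1 both carry the hydroxy group, so the earlier step could not show what this group contributes. Replacing it with hydrogen on the aromatic carbon now gives a 2.6-fold higher number from compound 2 to compound 3 (0.42 log units; beyond the scatter) in this assay and shows that growth inhibition in this series does respond to this one change. The hydroxy group alone does not set the order, however: with a 2.2-fold lower number from compound 1 to compound 3 (0.35 log units; beyond the scatter) as the step between them, the benzyl group without a hydroxy group still gives a lower number than the 4-hydroxyphenyl group with one, so the link between the nitrogen and the ring also matters in this comparison. Nothing available explains why either number moves.

Going by these compounds, it remains open whether only the hydroxy group gives this result, or whether a methoxy group, a fluorine atom or an amine on the same aromatic carbon would read like compound 2 or like compound 3. Also open, on these data alone, is how this assay would respond to a plain phenyl group or a longer chain, such as 2-phenylethyl, on the amide-type nitrogen.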